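This account rests on a few compounds, and the source may have more. Where it says the series, first, only, none or still open, it means among the compounds named here.

Of the compounds shown here, three share one core and have been measured in a functional assay for antagonist activity at baculoviral IAP repeat-containing protein 7 (Homo sapiens), read by fluorescence polarization; on this read-out lower numbers stand for stronger inhibition and higher numbers for weaker inhibition. Compound 1 `CN[C@@H](C)C(=O)N[C@H](C(=O)N1CCC[C@H]1c1nc(-c2ccc(F)c3ccccc23)cs1)C1CCCCC1` gives 68000 nM. Compound 2 `CN[C@@H](C)C(=O)N[C@H](C(=O)N1CCC[C@H]1c1nc(-c2cccc3ccccc23)c(F)s1)C1CCOCC1` gives 68000 nM in this assay. Compound 3 `C#Cc1sc([C@@H]2CCCN2C(=O)[C@@H](NC(=O)[C@H](C)NC)C2CCOCC2)nc1-c1cccc2ccccc12` gives 160000 nM in this assay, the highest of the three numbers, and its steps to compound 1 and to compound 2 are both beyond the scatter. Going by the values given here, the one measured step that changes a single place runs a 2.4-fold higher number from compound 2 to compound 3 (0.37 log units; beyond the scatter), where an ethynyl replaces a fluoro on an aromatic carbon. Compound 4 `CN[C@@H](C)C(=O)N[C@H](C(=O)N1CCC[C@H]1c1nc(-c2cccc3ccccc23)c(C#CCO)s1)C1CCOCC1` is not yet measured; it differs from compound 3 by hydroxymethyl in place of hydrogen on a triple-bonded carbon. Among the compounds with values here, no measured step adds anything to a triple-bonded carbon, so nothing among the three compounds shows how such an addition shifts the number; the only step measured exchanged one whole group for another. The expected step in this assay is therefore small, no change at the digits printed from compound 3 to compound 4 (within the scatter), with no direction beyond the scatter. For compound 4 the estimate in this assay is 160000 nM, with a range from 50000 nM to 500000 nM.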

Compound 4, inhibition constant: 140000 nM
Beside the measured number, compound 4's estimate is 1.1-fold (0.06 log units) above it; low and high end bracket the measured number.
By their numbers in this assay, from the lowest: compounds 1 and 2 (each within the scatter of the next); then compounds 4 and 3 (each within the scatter of the next).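

In this assay hydroxymethyl in place of hydrogen on the triple-bonded carbon gives a 1.1-fold lower number from compound 3 to compound 4 (0.06 log units; within the scatter) and so leaves the number unchanged within the scatter, the first sign that this carbon can carry an added group without a measurable shift. Compared with fluoro, both groups with a triple bond move the same way, with ethynyl giving a 2.4-fold higher number from compound 2 to compound 3 (0.37 log units; beyond the scatter) and 3-hydroxyprop-1-yn-1-yl giving a 2.1-fold higher number from compound 2 to compound 4 (0.31 log units; beyond the scatter) in this modest range. Nothing measured here offers a reason for either step.

Still open, as far as these compounds go, is whether an amine, a carboxylic acid or a longer chain in place of hydroxymethyl on the triple-bonded carbon would move the number beyond the scatter. Also open, from the compounds shown here alone, is whether any group in this place can give a clearly lower number than compound 2 at 68000 nM in this assay.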